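The compounds below may be only part of what the source reports. "The series", "measured", "known", "first", "only" and "open" are said of these compounds alone.

Working notes on the series, read in an ADME assay on HepG2 cells (Homo sapiens) for cytotoxicity, read by MTT assay, with a stated time of 72 h; a lower number here means that less compound is tolerated, a higher number that more compound is tolerated. Compound 1 (`CCCCCCNc1nc2cc(-c3ccc(C)cc3)sc2c(=O)[nH]1`) gives 10600 nM and compound 2 (`Cc1ccc(-c2cc3nc(NCC(C)C)[nH]c(=O)c3s2)cc1`) gives 21600 nM, the higher of the two numbers. Next comes compound 3 (`CCCCN(C)c1nc2cc(-c3ccc(C)cc3)sc2c(=O)[nH]1`), with butyl(methyl)amino in place of isobutylamino on an aromatic carbon, between two ring nitrogen atoms: butyl(methyl)amino in place of isobutylamino on an aromatic carbon. Within the data shown here, one measured step bears on this change: a 2.0-fold higher number from compound 1 to compound 2 (0.31 log units; beyond the scatter). It is modest, and it concerns the chain only. Among the measured compounds shown here, no measured compound shows the loss of the hydrogen on the amino nitrogen, so that part of the change remains untested. Compound 3 has an unbranched chain, as compound 1 does, which points to a small move towards the lower number of compound 1, 10600 nM. The expected step is a 1.8-fold lower number from compound 2 to compound 3 (0.26 log units; within the scatter). Compound 3 is estimated at 12000 nM, with an expected range of 5500 nM to 26000 nM.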

Compound 3, half-maximal cytotoxic concentration: 3000 nM
Compound 3: middle estimate off by 4.0-fold (0.60 log units), on the high side; the whole stated range lies above it.
By their numbers in this assay, from the lowest: compound 3; then compound 1; then compound 2.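

In this assay the change to butyl(methyl)amino gives a 7.2-fold lower number from compound 2 to compound 3 (0.86 log units; beyond the scatter) and, set against hexylamino, gives a 3.5-fold lower number from compound 1 to compound 3 (0.55 log units; beyond the scatter) and so places compound 3 lowest of the three, with both steps beyond the scatter. Among these compounds, an unbranched chain alone does not set the number at this aromatic carbon: compound 1 and compound 3 both carry one and still lie apart, and the only group here with 0 hydrogen-bond donors stands lowest. Nothing on hand explains this drop.

The compounds shown leave open how much of the step belongs to the loss of the hydrogen on the amino nitrogen and how much to the chain, as both change together. Hexyl(methyl)amino, dimethylamino or a ring amine such as morpholine at this place would bear on that question.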